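Cytotoxicity of Oxazolidinone Analogues: An Unmeasured Amide Variant

The source may hold more compounds than are shown below. What is called first, only, known or untested is meant among the compounds shown, and "the series" means these compounds.

Compound 1 `O=C1O[C@@H](CN2CCCCC2)CN1c1ccc(-n2cc(-c3ccccn3)cn2)c(F)c1` gives > 400 ug/mL in an ADME assay on L02 cells (Homo sapiens) for cytotoxicity, read by MTT assay, with a stated time of 48 h (on this read-out lower numbers stand for stronger inhibition and higher numbers for weaker inhibition), a limit of the assay rather than a number.
Compound 2 `O=C(OC[C@H]1CN(c2ccc(-n3cc(-c4ccccn4)cn3)c(F)c2)C(=O)O1)c1ccccc1` gives > 400 ug/mL in this assay, again a limit.
Compound 3 `COC[C@H]1CN(c2ccc(-n3cc(-c4ccccn4)cn3)c(F)c2)C(=O)O1` gives > 400 ug/mL in this assay, also a limit.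

Within the data shown here, compound 3 therefore stands at the limit shared by every compound measured so far, as the limit of > 400 ug/mL in this assay, at which 3 of the 3 values shown sit, shows; it cannot be placed above or below compound 1 or compound 2. From the compounds shown here alone, the three measured steps, a step that the two limits leave unreadable from compound 1 to compound 2, a step that the two limits leave unreadable from compound 1 to compound 3, and a step that the two limits leave unreadable from compound 2 to compound 3, are each left unreadable by the two limits, so their sizes are unknown.

Compound 4 `CNC(=O)[C@H]1CN(c2ccc(-n3cc(-c4ccccn4)cn3)c(F)c2)C(=O)O1` differs from compound 3 as follows: methylcarbamoyl in place of methoxymethyl on a saturated ring carbon. Among the measured compounds shown here, no measured step bears directly on this change, since none involves a methylcarbamoyl group, and the steps that exist give no readable size. With every value resting at the limit, the expectation for compound 4 in this assay is a step that the limit leaves unreadable from compound 3 to compound 4, that is, none beyond the scatter. The estimate for compound 4 is 450 ug/mL, expected within 300 ug/mL to 700 ug/mL, most likely reported again as a limit.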

Compound 4, half-maximal inhibitory concentration: 217 ug/mL
For compound 4 the middle estimate is 2.1-fold (0.32 log units) above the measured one; measured number below the stated range.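

Compound 4 is the only compound here that gives a number rather than a limit in this assay, so a change on the saturated ring carbon next to the ring oxygen can now be seen on this read-out, while the other compounds stay at a shared limit: the limit of > 400 ug/mL in this assay, at which 3 of the 4 values shown sit.

Methylcarbamoyl in place of methoxymethyl gives an at least 1.8-fold lower number from compound 3 to compound 4 (0.26 log units; that floor lies within the scatter), and the replacements of the two other groups give an at least 1.8-fold lower number from compound 2 to compound 4 (0.26 log units; that floor lies within the scatter) and an at least 1.8-fold lower number from compound 1 to compound 4 (0.26 log units; that floor lies within the scatter). Each of these is only a floor that lies within the usual scatter, and the steps among compound 1, compound 2 and compound 3 cannot be read.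

Still open, from the compounds shown here alone, is whether the number follows the amide hydrogen, the carbonyl or the methyl group. A dimethylcarbamoyl group, an unsubstituted carbamoyl group or a carboxylic acid on this carbon would separate these possibilities.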